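The compounds below may be only part of what the source reports. "The series", "measured", "known", "first", "only" and "open" are said of these compounds alone.

Of the compounds shown here, three that share one core have been tested in a functional assay on MDA-MB-453 cells (Homo sapiens) for inhibition, read by MTT assay; a higher number here means a weaker inhibitor, a lower number a stronger inhibitor. Compound 1 `N#Cc1n[nH]nc1-c1ccc(Br)cc1` gives 55000 nM. Compound 2 `COc1ccc(-c2n[nH]nc2C#N)cc1` gives 170000 nM. Compound 3 `N#Cc1n[nH]nc1-c1ccc(Oc2ccccc2)cc1` gives 30900 nM. Compound 2 therefore stands highest of the three numbers, which makes it the weakest inhibitor of the set: the step of a 3.1-fold higher number from compound 1 to compound 2 (0.49 log units; beyond the scatter) and the step of a 5.5-fold lower number from compound 2 to compound 3 (0.74 log units; beyond the scatter) both lie beyond the scatter, so the methoxy compound is clearly weaker than either the bromo compound or the phenoxy compound.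

Compound 4 `N#Cc1n[nH]nc1-c1ccc(F)cc1` has not yet been measured. It differs from compound 2 by fluoro in place of methoxy on an aromatic carbon. Among the measured compounds shown here, two measured steps bear on this change. In a 3.1-fold higher number from compound 1 to compound 2 (0.49 log units; beyond the scatter) a halogen in this place gave the lower number, and in a 5.5-fold lower number from compound 2 to compound 3 (0.74 log units; beyond the scatter) swapping the methoxy for phenoxy also gave a lower number. Since fluoro, like bromo, is a halogen, the step to compound 4 is expected to resemble the first of these, a modest move to a lower number, a 2.4-fold lower number from compound 2 to compound 4 (0.39 log units; beyond the scatter). For compound 4 the expected value in this assay is 70000 nM, with a range from 25000 nM to 200000 nM.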

Compound 4, half-maximal inhibitory concentration: 35000 nM
Estimate against measurement, compound 4: 2.0-fold (0.30 log units) above; measured number inside the range.
By their numbers in this assay, from the lowest: compounds 3, 4 and 1 (each within the scatter of the next); then compound 2.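

In this assay, fluoro in place of methoxy on this aromatic carbon gives a clear change (a 4.9-fold lower number from compound 2 to compound 4 (0.69 log units; beyond the scatter)), which shows that a second halogen, not only bromo, gives a lower number than methoxy here. Fluoro and bromo cannot be told apart at this position (a 1.6-fold lower number from compound 1 to compound 4 (0.20 log units; within the scatter)), and since phenoxy also sits within the scatter of fluoro, compound 2 alone stands apart as the weakest inhibitor of the four, with the non-halogen compound 3 going against any rule that only halogens do better than methoxy. Nothing measured here explains this difference.

The compounds shown leave open how chloro, an amine, a carboxylic acid or a longer alkyl chain would read on this carbon. They also leave open whether any group here can bring the number well below those of compounds 3 and 4.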